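Dichloro variant of the imide-piperazine amide series

A few compounds are considered here, and "the series" means these few. Any claim that something is new, unique, unknown or untested is made for them only; others in the source may bear on it.

Three compounds on a shared core are on record. Compound 1 `CC1(c2ccccc2)CC(=O)N(CC(=O)N2CCN(c3ccccc3F)CC2)C1=O` is reported as "not active" (no number reported) in a functional assay on the whole organism (strain CD-1) with Mus musculus as the target, in the maximal electroshock model, with a stated time of 2 h; a lower number here means that less compound is needed, a higher number that more compound is needed for the effect. Compound 2 `CC1(c2ccccc2)CC(=O)N(CC(=O)N2CCN(c3cccc(Cl)c3)CC2)C1=O` gives 300 mg/kg in this assay. For the measured compounds named here, compound 3 `CC1(c2ccccc2)CC(=O)N(CC(=O)N2CCN(c3ccccc3Cl)CC2)C1=O` is reported as "not active" (no number reported) in this assay, so no number stands for it and no step to another compound can be sized from it.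

The next compound, compound 4 `CC1(c2ccccc2)CC(=O)N(CC(=O)N2CCN(c3cccc(Cl)c3Cl)CC2)C1=O`, differs from compound 3 by chloro in place of hydrogen on an aromatic carbon; read one bond further out, the change is 2-chlorophenyl to 2,3-dichlorophenyl. Going by the values given here, since compound 3 carries no number in this assay, the size of the step cannot be stated from data; the only anchor for a number on this core is compound 2 with 300 mg/kg, and it is uncertain whether compound 4 reaches a measurable dose at all.

Compound 4 is expected to give about 300 mg/kg in this assay, with a range from 100 mg/kg to 600 mg/kg, and a substantial chance that only inactivity is reported.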

Compound 4, minimum effective dose: "not active" (no number reported)
The entry for compound 4 holds no number, so the estimate cannot be set against anything.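

Compound 3 and compound 4 both stand without a number in this assay, so no step can be read between them. No evidence on record bears on this result. Still open, from the compounds shown here alone, is what size the change from 2-chlorophenyl to 2,3-dichlorophenyl has on the shared core.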